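The source may report more compounds than this note shows. Statements on the series, on what has been measured and on what is new or still open speak of the compounds shown alone.

Compound 1 `CC(=NNC(=S)Nc1ccccc1F)c1ccccn1` gives 5 nM in a functional assay on U-87MG ATCC cells (Homo sapiens) for cytotoxicity, read by MTT assay, with a stated time of 48 h; on this read-out lower numbers stand for stronger inhibition and higher numbers for weaker inhibition.
Compound 2 `CC(=NNC(=S)Nc1ccccc1[N+](=O)[O-])c1ccccn1` gives 4.3 nM in this assay.
Compound 3 `C/C(=N/NC(=S)Nc1ccc([N+](=O)[O-])cc1)c1ccccn1` gives 160 nM in this assay.

Compounds 1 and 2 share one core; the values of compound 1 and compound 2 lie within the scatter of each other. Compound 3 has the same atoms as compound 2 joined differently, and the difference between the two cores is not broken down here. Among the measured compounds shown here, compound 3 stands well apart: a 1.2-fold higher number from compound 2 to compound 1 (0.07 log units; within the scatter) is the only measured step, while compound 3 sits far above both compound 1 and compound 2, beyond the scatter.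

Compound 4 `C/C(=N/NC(=S)Nc1ccc(F)cc1)c1ccccn1` is not yet measured. It differs from compound 3 by fluoro in place of nitro on an aromatic carbon. The same kind of change, (fluoro in place of nitro on an aromatic carbon), was measured between compound 2 and compound 1, and there it was a 1.2-fold higher number from compound 2 to compound 1 (0.07 log units; within the scatter). The place differs, however: ortho to a large group in one case, para to a large group in the other, so the two changes are of the same kind but not the same.

Compound 4 is estimated at 130 nM, with the range 35 nM to 500 nM in this assay. This expected step a 1.2-fold lower number from compound 3 to compound 4 (0.09 log units; within the scatter) rests mainly on compound 3 at 160 nM and on the small size of a 1.2-fold higher number from compound 2 to compound 1 (0.07 log units; within the scatter). The range is kept wide: the place of the change is not the same in the two cases.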

Compound 4, half-maximal inhibitory concentration: 10 nM
Compound 4: middle estimate off by 13-fold (1.11 log units), on the high side, and the stated range ends above it.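

Fluoro in place of nitro on an aromatic carbon gives a 16-fold lower number from compound 3 to compound 4 (1.20 log units; beyond the scatter) in this assay and so does not carry over as one fixed step in this series. Set beside the earlier step on the other core, the size of this change clearly depends on the compounds that carry it: the same change on two cores in this assay, a 1.2-fold higher number (0.07 log units; within the scatter) from compound 2 to compound 1 and a 16-fold lower number (1.20 log units; beyond the scatter) from compound 3 to compound 4, 19-fold (1.27 log units) apart, beyond the scatter of two such steps

Going by these compounds, a small step on one core therefore gave no safe guide to the step on the other, though the direction and size of the change on further cores remain unknown. The comparison does not show what sets the two steps apart, as the change is para to a large group in compound 4 and sits elsewhere on the other core, so place and core cannot be separated here.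

The compounds shown leave open how the step would read with both groups at the same place on each core. They also leave open whether a chloro group, a methoxy group or an amine at that place would follow fluoro or nitro.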